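Amide substituent variation in a paw edema series

A few compounds are considered here, and "the series" means these few. Any claim that something is new, unique, unknown or untested is made for them only; others in the source may bear on it.

Measured so far:
compound 1 `CCCCNC(=O)c1c(O)c2cccnc2n(-c2ccccc2)c1=O`: 12.8%
compound 2 `O=C(Nc1cccc(Cl)c1)c1c(O)c2cccnc2n(-c2ccccc2)c1=O`: 7.6%

In a functional assay on the whole organism for inhibition, with Rattus norvegicus as the target, read by paw edema, at a dose of 100 mg/kg by the oral route (on this read-out higher numbers stand for more inhibition at the one dose given (going by the name of the read-out) and lower numbers for less inhibition), compound 2 gives 7.6%, and compound 1 gives 12.8%. The two values lie within the usual scatter of each other, as the step of a number 5.2 percentage points lower from compound 1 to compound 2 (within the scatter) shows. Compound 3 `O=C(NCc1ccncc1)c1c(O)c2cccnc2n(-c2ccccc2)c1=O` differs from compound 2 by (pyridin-4-yl)methyl in place of 3-chlorophenyl on an amide-type nitrogen. Among the compounds with values here, no measured step covers this change; the only recorded step, a number 5.2 percentage points lower from compound 1 to compound 2 (within the scatter), concerns a different exchange at the same nitrogen and stayed within the scatter. For compound 3 the expected step is a number 2.4 percentage points higher from compound 2 to compound 3 (within the scatter), nothing beyond the scatter. Compound 3 is estimated at 10%, within 0% to 25%.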

Compound 3, a percentage reported as inhibition, in the whole organism at one dose (the size of the read-out at that dose, not a potency): 10%
Compound 3: middle estimate and measured number agree at the digits printed; the measured number falls inside the stated range.
By their numbers in this assay, from the lowest: compounds 2, 3 and 1 (each within the scatter of the next).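

In this assay the step of a number 2.4 percentage points higher from compound 2 to compound 3 (within the scatter) comes with (pyridin-4-yl)methyl in place of 3-chlorophenyl on the amide-type nitrogen, and the step of a number 2.8 percentage points lower from compound 1 to compound 3 (within the scatter) comes with pyridin-4-yl in place of propyl on the saturated chain carbon. A six-membered aromatic ring with a hetero atom and a hydrogen-bond acceptor is thus carried at this nitrogen, with neither step beyond the scatter. As far as these compounds go, whether a carboxylic acid, an amine or a longer chain on this nitrogen would give a step beyond the scatter remains open. Nothing available explains these numbers.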